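A few compounds are considered here, and "the series" means these few. Any claim that something is new, unique, unknown or untested is made for them only; others in the source may bear on it.

In a functional assay on U-373MG ATCC cells for cytotoxicity against U373 MG (Homo sapiens), read by colorimetric assay and MTT assay (a higher number here means a weaker inhibitor, a lower number a stronger inhibitor), the measured compounds read as follows.

Compound 1 `COc1cccc2cc(-c3ccccc3)c(O)nc12` gives 10000 nM
Compound 2 `COc1ccc2cc(-c3ccccc3)c(O)nc2c1` gives 10000 nM
Compound 3 `CCN(CC)C(=O)Cn1c(=O)c(-c2ccc(OC)cc2)cc2c(OC)cc(OC)cc21` gives 10000 nM

Compound 3 thus stands level with compound 1 and compound 2 at the digits shown, and the three values cannot be told apart in this assay. The next compound, compound 4 `CCN(CC)C(=O)CCn1c(=O)c(-c2ccc(OC)cc2)cc2c(OC)cc(OC)cc21`, differs from compound 3 in one place, on a saturated chain carbon bound to an aromatic nitrogen: (diethylcarbamoyl)methyl in place of diethylcarbamoyl on a saturated chain carbon bound to an aromatic nitrogen. Read one bond further out, this is (diethylcarbamoyl)methyl going to 2-(diethylcarbamoyl)ethyl.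

Within the data shown here, no pair of measured compounds differs in one place only, so the data offer no direct gauge for this change. The expectation rests on compound 3 at 10000 nM as the starting point, and no step beyond the usual scatter is expected in this assay. The expected move is no change at the digits printed from compound 3 to compound 4 (within the scatter) in size. Compound 4 is estimated at 10000 nM, with an expected range from 3500 nM to 20000 nM.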

Compound 4, half-maximal inhibitory concentration: 10000 nM
For compound 4 middle estimate and measured number coincide at the digits printed; low and high end bracket the measured number.
By their numbers in this assay, from the lowest: compounds 1, 2, 3 and 4 (each within the scatter of the next).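

In this assay, the change from (diethylcarbamoyl)methyl to 2-(diethylcarbamoyl)ethyl gives the first reading of a single change among these compounds: no change at the digits printed from compound 3 to compound 4 (within the scatter). At this place, on a saturated chain carbon bound to an aromatic nitrogen, the longer chain leaves the amide end in place, and compound 4 gives 10000 nM in this assay. No supporting measurement bears on why this change leaves the value where it stood.

Still open, as far as these compounds go, is whether a carboxylic acid or an amine at the end of the chain, or a longer chain, would give a value that differs from that of compound 4 in this assay. Compounds 1 and 2 differ from compound 4 in more than one place, so they add nothing on this question.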